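The source may hold more compounds than are shown below. What is called first, only, known or untested is meant among the compounds shown, and "the series" means these compounds.

Working notes on the series. In a functional assay on HCT-116 cells (Homo sapiens) for cytotoxicity, read by MTT assay, with a stated time of 72 h (on this read-out higher numbers stand for weaker inhibition and lower numbers for stronger inhibition), compound 1 `N[C@H]1CC[C@H](Nc2c(C(=O)NCc3ccc(F)cc3)nc(N3CCCCC3)c3cccnc23)CC1` gives 8000 nM. Compound 2 `O=C(NCc1ccc(F)cc1)c1nc(Br)c2cccnc2c1NCc1ccccc1` is measured only as a limit in this assay, > 20000 nM, and not as a number. Compound 3 `O=C(NCc1ccc(F)cc1)c1nc(NCCO)c2cccnc2c1O` is the other entry of the set without a single number, its result in this assay being "not determined" (no result reported). So among the three entries shown, compound 2 stands at the limit rather than at a value, as recorded in the limit of > 20000 nM in this assay, at which 1 of the 3 values shown sits.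

Compound 4 `CN(C)CCCNc1c(C(=O)NCc2ccc(F)cc2)nc(Br)c2cccnc12` is not yet measured. It differs from compound 2 in one place, (2-(dimethylamino)ethyl in place of phenyl on a saturated chain carbon bound to a nitrogen on an aromatic ring).

For the measured compounds named here, no step between measured compounds is available for this series, so the size of the change from compound 2 to compound 4 cannot be read from a measured pair. Going by the values given here, compound 1 at 8000 nM gives the one single number seen so far. For compound 4 the expected step is an at least 1.6-fold lower number from compound 2 to compound 4 (0.22 log units; that floor lies within the scatter), a modest gain beyond the scatter, pointing toward a number rather than a limit. The estimate for compound 4 in this assay is 12000 nM, within 4000 nM to 40000 nM.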

Compound 4, half-maximal inhibitory concentration: > 10000 nM
Compound 4: a limit, no number; the forecaster's own chance of this, stated with the estimate: 35%; the middle value does not contradict the limit.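

Compound 2 and compound 4 both stand only as limits in this assay, so no step can be read between them. The compounds shown leave open what single number either would give, and whether benzyl to 3-(dimethylamino)propyl shifts the read-out at all.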